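The compounds below may be only part of what the source reports. "The series", "measured", "known", "first", "only" and "open" are said of these compounds alone.

Three compounds share one core and differ only in one substituent. Compound 1 `N#Cc1cc(C(=O)N2CC=CC2)cc(Cl)c1O` gives 66% in an assay on isolated protein for inhibition of solute carrier family 22 member 12 (Homo sapiens), tested at 3 uM; a lower number here means less inhibition, a higher number more inhibition at the concentration tested (going by the name of the read-out). Compound 2 `Cc1cc(C(=O)N2CC=CC2)cc(C#N)c1O` gives 25% in this assay. Compound 3 `N#Cc1cc(C(=O)N2CC=CC2)cc(Br)c1O` gives 69% in this assay, the highest of the three numbers, although its gap to compound 1 stays within the scatter: a number 3 percentage points higher from compound 1 to compound 3 (within the scatter). Compound 4 `CC(C)(C)c1cc(C(=O)N2CC=CC2)cc(C#N)c1O` is not yet measured; it differs from compound 3 in one place: tert-butyl in place of bromo on an aromatic carbon. Among the compounds with values here, two measured steps bear on this change, each exchanging chloro or bromo for methyl: a number 41 percentage points lower from compound 1 to compound 2 (beyond the scatter) and a number 44 percentage points higher from compound 2 to compound 3 (beyond the scatter). Both were large, and the number of the methyl compound was the lower one each time. Within the data shown here, a fall of similar size is therefore expected, a number 41 percentage points lower from compound 3 to compound 4 (beyond the scatter), though no measured compound carries tert-butyl. Compound 4 is estimated at 28%, within 8% to 52%.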

Compound 4, a percentage reported as inhibition, at one concentration (the size of the read-out at that concentration, not a potency): 92%
Compound 4: the middle estimate sits 64 percentage points below what was measured, and the stated range ends below it.
By their numbers in this assay, from the lowest: compound 2; then compounds 1 and 3 (each within the scatter of the next); then compound 4.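

Methyl's low number does not extend to every carbon group at this position: in this assay tert-butyl gives a number 67 percentage points higher from compound 2 to compound 4 (beyond the scatter). Tert-butyl also exceeds both halogens, with a number 23 percentage points higher from compound 3 to compound 4 (beyond the scatter) and a number 26 percentage points higher from compound 1 to compound 4 (beyond the scatter), so the order among these four groups does not simply set halogens above carbon groups. No measurement here explains this difference between methyl and tert-butyl. Still open, going by these compounds, is how the number behaves between these two carbon groups, as with ethyl or isopropyl, and whether a methoxy group or an amine at this position would give a high number.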